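Swapping bromo for trifluoromethyl on a thioamide core

The compounds below may be only part of what the source reports. "The series", "measured", "known", "first", "only" and "open" are said of these compounds alone.

Compound 1 `COc1cc(Cl)ccc1C(=O)Nc1cc(Br)ccc1O` gives 5630 nM in a functional assay on HepG2 cells (Homo sapiens) for cytotoxicity, with a stated time of 24 h; on this read-out lower numbers stand for stronger inhibition and higher numbers for weaker inhibition. Compound 2 `COc1cc(Cl)ccc1C(=O)Nc1cc(C(F)(F)F)ccc1O` gives 25400 nM. Compound 3 `COc1cc(Cl)ccc1C(=S)Nc1ccc(Br)cc1O` gives 3880 nM.

The change from compound 1 to compound 2 is trifluoromethyl in place of bromo on an aromatic carbon, and it made a 4.5-fold higher number from compound 1 to compound 2 (0.65 log units; beyond the scatter). Compound 4 `COc1cc(Cl)ccc1C(=S)Nc1ccc(C(F)(F)F)cc1O` carries the same kind of change on the core of compound 3: trifluoromethyl in place of bromo on an aromatic carbon. The surroundings differ, since in compound 2 the new group sits meta to a large group and para to a hydroxy group, while in compound 4 it sits meta to a hydroxy group and para to a large group. How the core of compound 3 differs from that of compound 1 is not broken down here. On the basis of compound 1 to compound 2, the expected step is a 4.1-fold higher number from compound 3 to compound 4 (0.62 log units; beyond the scatter). Compound 4 is expected to give about 16000 nM, likely between 6000 nM and 45000 nM in this assay.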

Compound 4, half-maximal inhibitory concentration: 3140 nM
Estimate against measurement, compound 4: 5.1-fold (0.71 log units) above; measured number outside the range, below it.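

In this assay, putting trifluoromethyl in place of bromo gives a 1.2-fold lower number from compound 3 to compound 4 (0.09 log units; within the scatter), so on this core the two numbers cannot be told apart. The swap therefore did not act the same way on the two cores: the same change on two cores in this assay, a 4.5-fold higher number (0.65 log units; beyond the scatter) from compound 1 to compound 2 and a 1.2-fold lower number (0.09 log units; within the scatter) from compound 3 to compound 4, 5.6-fold (0.75 log units) apart, beyond the scatter of two such steps. This shows that a step seen on one core cannot simply be assumed on the other in this series, but it does not show which difference between the cores lies behind the gap, and each step rests on a single pair of compounds.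

Still open, as far as these compounds go, is how a nitrile or a methyl group in the place of bromo would fare on either core.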